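The source may report more compounds than this note shows. Statements on the series, on what has been measured and on what is new or still open speak of the compounds shown alone.

Working notes on the series.

Compound 3 `Nc1sc(-c2ccc(Cl)cc2)c(-c2ccc(Cl)cc2)c1C(=O)N1CCNCC1` gives 1020 nM in a functional assay on A549 cells (Homo sapiens) for inhibition, read by sulforhodamine B assay, with a stated time of 72 h; a lower number here means a stronger inhibitor, a higher number a weaker inhibitor. Among the compounds with values here, on the three numbers so far it stands second highest: compound 1 `Nc1sc(-c2ccc(Cl)cc2)c(-c2ccc(Cl)cc2)c1C(=O)N1CCCC1` gives 890 nM, and compound 2 `CCOC(=O)Nc1sc(-c2ccc(Cl)cc2)c(-c2ccc(Cl)cc2)c1C(=O)NC1CC1` gives 39800 nM. Within the data shown here, the only single-point step measured, a 1.1-fold higher number from compound 1 to compound 3 (0.06 log units; within the scatter), stays within the scatter, so swapping one cyclic amine on the carbonyl carbon for another did nothing visible. Compound 2 differs from compound 3 in two places at once, so its far weaker number cannot be assigned to either change.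

Compound 4 `COc1ccc(CNC(=O)c2c(N)sc(-c3ccc(Cl)cc3)c2-c2ccc(Cl)cc2)cc1` is the next step: (4-methoxybenzyl)amino in place of piperazin-1-yl on a carbonyl carbon. Among the measured compounds shown here, this again alters only the group on the carbonyl carbon, and the one comparable step, from compound 1 to compound 3, was flat. For the measured compounds named here, no measured pair shows an open-chain amine in this position, so the change is wider than anything tested, and a larger spread must be allowed. For compound 4 a step of a 1.2-fold higher number from compound 3 to compound 4 (0.07 log units; within the scatter) is expected, leaning toward no change beyond the scatter. The estimate for compound 4 in this assay is 1200 nM, with a range from 400 nM to 4000 nM.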

Compound 4, half-maximal inhibitory concentration: 18200 nM
Estimate against measurement, compound 4: 15-fold (1.18 log units) below; measured number outside the range, above it.
By their numbers in this assay, from the lowest: compounds 1 and 3 (each within the scatter of the next); then compound 4; then compound 2.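

In this assay the group on the carbonyl carbon proves not to be indifferent: (4-methoxybenzyl)amino in place of piperazin-1-yl gives an 18-fold higher number from compound 3 to compound 4 (1.25 log units; beyond the scatter) and in place of pyrrolidin-1-yl gives a 20-fold higher number from compound 1 to compound 4 (1.31 log units; beyond the scatter) and both steps are large. The flat exchange between the two cyclic amines therefore does not extend to every group at this position, and the weaker number comes with the loss of the non-aromatic ring and the entry of an aromatic one. No measurement is available that explains this loss of activity.

The compounds shown leave open whether the weaker number follows from the open-chain amine itself, from the benzyl part or from the methoxy group. A small open-chain group such as methylamino and an unsubstituted benzylamino group on the same carbonyl carbon would separate these possibilities.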